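A few compounds are considered here, and "the series" means these few. Any claim that something is new, unique, unknown or untested is made for them only; others in the source may bear on it.

Measured in a toxicity assay on Huh-7.5 cells (Homo sapiens) for inhibition, read by MTT assay, with a stated time of 96 h; on this read-out higher numbers stand for lower toxicity in this test and lower numbers for higher toxicity in this test:
- compound 1 (`CC(C)Oc1ccc(C(=O)Nc2ccc(N(C)C)cc2)cc1[N+](=O)[O-]`): 50000 nM
- compound 2 (`CC(C)Oc1ccc(C(=O)Nc2ccc(N(C)C)cc2)cc1N`): 72100 nM
- compound 3 (`CCC(=O)Nc1cc(C(=O)Nc2ccc(N(C)C)cc2)ccc1OC`): 171000 nM

Compound 3 has the highest number of the three, so it is the least toxic in this test. Compound 4 (`CCC(=O)Nc1cc(C(=O)Nc2ccc(N(C)C)cc2)ccc1OC(C)C`) changes it in one place: isopropyl in place of methyl on an oxygen on an aromatic ring. Among the compounds with values here, no measured step makes this exact change. Within the data shown here, the only step, a 1.4-fold higher number from compound 1 to compound 2 (0.16 log units; within the scatter), concerns another group and says little here. The best hint is indirect: compound 2, at 72100 nM, already carries the isopropoxy group, but it also differs from compound 3 elsewhere. A moderate move to a lower number is therefore expected, and the estimated step is a 1.6-fold lower number from compound 3 to compound 4 (0.21 log units; within the scatter). The estimate for compound 4 is 105000 nM, with an expected range from 50000 nM to 200000 nM.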

Compound 4, half-maximal cytotoxic concentration: 80600 nM
For compound 4 the middle estimate is 1.3-fold (0.11 log units) above the measured one, within the range that was stated.
By their numbers in this assay, from the lowest: compounds 1, 2 and 4 (each within the scatter of the next); then compound 3.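

In this assay the step from methoxy to isopropoxy on this oxygen can now be read directly, as a 2.1-fold lower number from compound 3 to compound 4 (0.33 log units; beyond the scatter) and so toward higher toxicity in this test. With isopropoxy in place, the neighbouring group shows no such effect: both a 1.1-fold higher number from compound 2 to compound 4 (0.05 log units; within the scatter) and a 1.6-fold higher number from compound 1 to compound 4 (0.21 log units; within the scatter) leave amino, nitro and propanoylamino indistinguishable. No measurement here accounts for the methoxy to isopropoxy shift. Still open, from the compounds shown here alone, is how a free hydroxyl or a longer chain such as butoxy on this oxygen would read, and whether the shift holds with amino or nitro in place of propanoylamino.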